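Ether substituent swap on the shared core, compound 2 to 3

The source may report more compounds than this note shows. Statements on the series, on what has been measured and on what is new or still open speak of the compounds shown alone.

Measured so far:
compound 1, `COc1ncc(-c2cc3c(C)nc(N)nc3n([C@H]3CC[C@H](OCCO)CC3)c2=O)cc1NS(=O)(=O)c1ccc(F)cc1F`, 360 nM
compound 2, `COc1ncc(-c2cc(OCC3CC3)c3nc(N)nc(C)c3c2)cc1NS(=O)(=O)c1ccc(F)cc1F`, 200 nM

Both compounds were run in a functional assay on NCI-H460 cells (Homo sapiens) for cytotoxicity, read by MTT assay, with a stated time of 96 h; on this read-out lower numbers stand for stronger inhibition and higher numbers for weaker inhibition. Compound 1 gives 360 nM and compound 2 gives 200 nM. Compound 2 has the lower of the two numbers, but its nearest neighbour, compound 1, lies within the scatter of it, so the two read as equivalent on present evidence. Among the measured compounds shown here, the two differ in the core as well as in the ether group, and no single-change step between them is available.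

Compound 3, `COc1ncc(-c2cc(OC3CCN(C)CC3)c3nc(N)nc(C)c3c2)cc1NS(=O)(=O)c1ccc(F)cc1F`, is not yet measured. It differs from compound 2 in one place: 1-methylpiperidin-4-yl in place of cyclopropylmethyl on an oxygen on an aromatic ring.

No comparable change has been measured in this series, so there is nothing to anchor the direction. The expectation is that the step of a 1.3-fold higher number from compound 2 to compound 3 (0.10 log units; within the scatter) stays within the scatter, with no reason from the data to expect a shift in either direction. Compound 3 is therefore estimated at 250 nM, with a range from 80 nM to 800 nM.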

Compound 3, half-maximal inhibitory concentration: 660 nM
Compound 3: middle estimate off by 2.6-fold (0.42 log units), on the low side; the range from low to high includes it.
By their numbers in this assay, from the lowest: compounds 2, 1 and 3 (each within the scatter of the next, the first and the last beyond it).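

In this assay, the ether on the shared core now has its first readable single change: cyclopropylmethoxy to (1-methylpiperidin-4-yl)oxy gives a 3.3-fold higher number from compound 2 to compound 3 (0.52 log units; beyond the scatter) and so weakens inhibition beyond the scatter, which shows that the group on this oxygen is not freely exchangeable. The change replaces a three-membered ring of carbon only with a six-membered ring holding one nitrogen, and this single pair cannot separate the contribution of the ring size from that of the nitrogen or its methyl group. Nothing available bears on the reason for the step at this position.

Open, going by these compounds, is whether the step follows the nitrogen or the ring itself: a cyclohexyl ether on the same oxygen would keep the six-membered ring without the nitrogen, while a piperidin-4-yl ether would keep the nitrogen without its methyl group. Also open, on these data alone, is whether a longer chain on this oxygen, such as a 2-methoxyethyl group, would stay close to compound 2 or move in the same direction as compound 3.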